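From a tert-butyl amide to a pyrrolidine amide

A few compounds are considered here, and "the series" means these few. Any claim that something is new, unique, unknown or untested is made for them only; others in the source may bear on it.

Measured so far:
Compound 1, `COC(=O)C1=C(C)NC(C)=C(C(=O)OC)C1c1ccc(OCC(=O)N2CCCCC2)c(OC)c1`: 10000 nM
Compound 2, `COC(=O)C1=C(C)NC(C)=C(C(=O)OC)C1c1ccc(OCC(=O)N2CCN(C)CC2)c(OC)c1`: 9100 nM
Compound 3, `COC(=O)C1=C(C)NC(C)=C(C(=O)OC)C1c1ccc(OCC(=O)NC(C)(C)C)c(OC)c1`: 2500 nM

All three compounds share the same core and differ only in the amide group attached to the carbonyl carbon. In an assay on cells for inhibition of Voltage-gated L-type calcium channel (Rattus norvegicus), read by fluorescence and calcium flux, with stated times of 30 min and 2 min (on this read-out lower numbers stand for stronger inhibition and higher numbers for weaker inhibition), compound 3 gives the lowest number of the three. Both measured steps that lead to it point the same way: a 4.0-fold lower number from compound 1 to compound 3 (0.60 log units; beyond the scatter) and a 3.6-fold lower number from compound 2 to compound 3 (0.56 log units; beyond the scatter). By contrast, the two cyclic amides sit together, as a 1.1-fold lower number from compound 1 to compound 2 (0.04 log units; within the scatter) shows.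

Compound 4, `COC(=O)C1=C(C)NC(C)=C(C(=O)OC)C1c1ccc(OCC(=O)N2CCCC2)c(OC)c1`, has not yet been measured. It differs from compound 3 in one place: pyrrolidin-1-yl in place of (tert-butyl)amino on a carbonyl carbon. This change takes away the hydrogen-bond donor of compound 3 and brings in a ring, so compound 4 resembles compound 1 and compound 2 more than compound 3. The steps from those two cyclic amides to compound 3 were modest but beyond the scatter, so the expected step is a modest rise in the number, a 3.2-fold higher number from compound 3 to compound 4 (0.51 log units; beyond the scatter). Compound 4 is therefore estimated at 8000 nM in this assay, with a likely range from 3000 nM to 20000 nM.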

Compound 4, half-maximal inhibitory concentration: 5600 nM
The estimate for compound 4 lay 1.4-fold (0.15 log units) above the measured number; the measured number falls inside the stated range.
By their numbers in this assay, from the lowest: compound 3; then compounds 4, 2 and 1 (each within the scatter of the next).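

In this assay the change from (tert-butyl)amino to pyrrolidin-1-yl swaps two groups with the same count of heavy atoms and still gives a 2.2-fold higher number from compound 3 to compound 4 (0.35 log units; beyond the scatter), so that count alone does not set the number at this place on the carbonyl carbon. The ring amides now form a set of three, with a 1.6-fold lower number from compound 2 to compound 4 (0.21 log units; within the scatter) and a 1.8-fold lower number from compound 1 to compound 4 (0.25 log units; within the scatter), which leaves compound 3, the only one of the four with an amide hydrogen and without a ring, on its own. Nothing measured here gives a reason for this step.

This step removes the amide hydrogen and adds the ring at once, so the two changes cannot be told apart. Dimethylamino, open-chain without an amide hydrogen, and cyclohexylamino, a ring that keeps the amide hydrogen, remain open.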